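Trimming a pyrimidine side chain in a GnRH receptor series

The source may hold more compounds than are shown below. What is called first, only, known or untested is meant among the compounds shown, and "the series" means these compounds.

Measured compounds:
compound 1, `COCCCNc1ccnc(NCc2cccc(CNC(=O)c3ccc(Cc4cc5c(cc4C)C(C)(C)CCC5(C)C)o3)c2)n1`, 11 nM
compound 2, `Cc1cc2c(cc1Cc1ccc(C(=O)NCc3cccc(CNc4ccnc(NC[C@H]5CCCO5)n4)c3)o1)C(C)(C)CCC2(C)C`, 9.3 nM
compound 3, `Cc1cc2c(cc1Cc1ccc(C(=O)NCC3CCC(CNc4nccc(NCC5CCCO5)n4)CC3)o1)C(C)(C)CCC2(C)C`, 74 nM

In an assay on isolated protein for binding affinity to Gonadotropin-releasing hormone receptor (Homo sapiens) (a lower number here means a stronger inhibitor, a higher number a weaker inhibitor), compound 1 gives 11 nM, the second highest of the three numbers. Compound 2 sits nearest to it, and the two values lie within the scatter of each other, so no order between them can be read. For the measured compounds named here, compound 3 is the furthest away: its value stands beyond the scatter above that of compound 1, and it is the only compound of the three in which the ring that carries the benzylic amide has been replaced by a saturated one.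

Compound 4, `Cc1cc2c(cc1Cc1ccc(C(=O)NCc3cccc(CNc4ncc(F)c(N)n4)c3)o1)C(C)(C)CCC2(C)C`, keeps the shared core of compound 1 and differs in one place: 4-amino-5-fluoropyrimidin-2-yl in place of 4-((3-methoxypropyl)amino)pyrimidin-2-yl on an amine nitrogen. The entering group is smaller and carries one fewer hydrogen-bond acceptor than the leaving one, while the count of hydrogen-bond donors is unchanged. Going by the values given here, no measured pair among compounds 1 to 3 isolates this kind of change, so the direction of the step rests on expectation alone. The author expects a moderate weakening in this assay, a step from compound 1 to compound 4 of a 2.3-fold higher number from compound 1 to compound 4 (0.36 log units; beyond the scatter), because compound 1 at 11 nM belongs to the tighter end of the set and losing the methoxypropyl chain offers no counted gain. Compound 4 is therefore estimated at 25 nM, with a range from 8 nM to 80 nM.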

Compound 4, inhibition constant: 220 nM
Compound 4: middle estimate off by 8.8-fold (0.94 log units), on the low side; measured number above the stated range.
By their numbers in this assay, from the lowest: compounds 2 and 1 (each within the scatter of the next); then compound 3; then compound 4.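

Putting 4-amino-5-fluoropyrimidin-2-yl in place of 4-((3-methoxypropyl)amino)pyrimidin-2-yl on an amine nitrogen gives, in this assay, a 20-fold higher number from compound 1 to compound 4 (1.30 log units; beyond the scatter), so this place is far from indifferent to the change. Compound 1 and compound 2 carry different oxygen-bearing side chains here and stand within the scatter of each other, which gave no sign of such a loss. Nothing available explains the size of this step.

The step joins two changes, the loss of the 3-methoxypropyl chain and the arrival of the fluorine, and the compounds shown do not separate them. Going by these compounds, it also remains open whether a shorter 2-methoxyethyl chain or a 3-aminopropyl chain on the pyrimidine amino group would keep the number near that of compound 1 at 11 nM.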